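Isopropylamino to isopropoxy: expected permeability of compound 3

The source may report more compounds than this note shows. Statements on the series, on what has been measured and on what is new or still open speak of the compounds shown alone.

Compound 1 `CC(C)NC(=O)N1CCC(CN(C2Cc3cc(C#N)ccc3N(Cc3cncn3C)C2)S(=O)(=O)c2ccccn2)CC1` gives 0.6 10^-6 cm/s in an ADME assay on Caco-2 cells (Homo sapiens) for permeability, in the apical to basolateral direction (on this read-out higher numbers stand for higher permeability and lower numbers for lower permeability), the lowest of the two numbers in the series. Compound 2 `Cn1cncc1CN1CC(N(CC2CCN(C(=O)OC(C)(C)C)CC2)S(=O)(=O)c2ccccn2)Cc2cc(C#N)ccc21` gives 15.5 10^-6 cm/s in this assay. For the measured compounds named here, the only measured change at this carbonyl carbon is a 26-fold higher number from compound 1 to compound 2 (1.41 log units; beyond the scatter), a large rise. Compound 3 `CC(C)OC(=O)N1CCC(CN(C2Cc3cc(C#N)ccc3N(Cc3cncn3C)C2)S(=O)(=O)c2ccccn2)CC1` differs from compound 1 by isopropoxy in place of isopropylamino on a carbonyl carbon. As in the step to compound 2, one hydrogen-bond donor leaves and one acceptor enters. For compound 3 a rise of similar size is expected, a 17-fold higher number from compound 1 to compound 3 (1.22 log units; beyond the scatter). Compound 3 is estimated at 10 10^-6 cm/s, within 4 10^-6 cm/s to 22 10^-6 cm/s.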

Compound 3, apparent permeability: 1 10^-6 cm/s
Estimate against measurement, compound 3: 10-fold (1.00 log units) above; the measured number lies below the stated range.
By their numbers in this assay, from the lowest: compounds 1 and 3 (each within the scatter of the next); then compound 2.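

At this carbonyl carbon, isopropoxy in place of isopropylamino does not reproduce the large rise seen with tert-butoxy: this assay gives a 1.7-fold higher number from compound 1 to compound 3 (0.22 log units; within the scatter). The difference between the tert-butoxy and isopropoxy carbamates, one methyl apart, is large, with a 16-fold lower number from compound 2 to compound 3 (1.19 log units; beyond the scatter), so the loss of the amide hydrogen alone does not account for the high number of compound 2. No available data explain this dependence on the alkyl group.

Open, going by these compounds, is whether tert-butylamino on the same carbonyl carbon would read like tert-butoxy or like isopropylamino. Also open, on these data alone, is where ethoxy and cyclobutoxy would fall in this assay.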